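Moving a methyl onto the phenol oxygen in two indanone series

The compounds below may be only part of what the source reports. "The series", "measured", "known", "first", "only" and "open" are said of these compounds alone.

Measured so far:
Compound 1 `COc1ccc(/C=C2\Cc3c(cc(OC)c(OC)c3OC)C2=O)cc1O` gives 570 nM in a functional assay on MDA-MB-231 cells (Homo sapiens) for antiproliferative activity, read by MTT assay, with a stated time of 48 h; on this read-out lower numbers stand for stronger inhibition of growth and higher numbers for weaker inhibition of growth.
Compound 2 `COc1ccc(/C=C2\Cc3c(cc(OC)c(OC)c3OC)C2=O)cc1OC` gives 9850 nM in this assay.
Compound 3 `COc1cc2c(cc1O)C(=O)/C(=C/c1cc(OC)c(OC)c(OC)c1)C2` gives only a limit, > 10000 nM, in this assay.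

Compound 1 and compound 2 differ by methyl in place of hydrogen on an oxygen on an aromatic ring, and that change gave a 17-fold higher number from compound 1 to compound 2 (1.24 log units; beyond the scatter). Compound 3 and compound 1 are built from the same atoms joined differently; the difference between the two cores is not broken down here. Among the measured compounds shown here, compound 4 `COc1cc2c(cc1OC)C(=O)/C(=C/c1cc(OC)c(OC)c(OC)c1)C2` differs from compound 3 by methyl in place of hydrogen on an oxygen on an aromatic ring, the same change in the same kind of place as the one between compound 1 and compound 2.

The value of compound 3 is itself a limit (the limit of > 10000 nM in this assay, at which 1 of the 3 values shown sits), so the step to compound 4 cannot be computed exactly. Given the weakening seen from compound 1 to compound 2, compound 4 is expected to stay at or beyond that limit, with an estimated step that the limit leaves unreadable from compound 3 to compound 4. Compound 4 is therefore estimated at 30000 nM, with an expected range from 8000 nM to 120000 nM.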

Compound 4, concentration for 50% growth inhibition: > 10000 nM
Compound 4: no number, only a limit (the forecaster's own chance of this, stated with the estimate: 85%); the middle value lies beyond the limit too.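

Compound 3 and compound 4 each give only a limit, not a number, so no step can be read between them: the limit of > 10000 nM in this assay, at which 2 of the 4 values shown sit.

The compounds shown leave open whether hydroxy to methoxy changes growth inhibition on the core of compound 3 as much as on the core of compound 1.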